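From Methyl to 4-Methylphenyl on the Ring Nitrogen

The source may report more compounds than this note shows. Statements on the series, on what has been measured and on what is new or still open speak of the compounds shown alone.

Compound 1 `CC#CC(CC(=O)O)c1ccc(OCc2ccc(C(=O)N3CCN(c4ccccc4)CC3)s2)cc1` gives 72 nM in a functional assay on HEK293 cells for agonist activity at Free fatty acid receptor 1 (Homo sapiens), read by fluorescence and calcium flux; on this read-out higher numbers stand for an effect only at larger amounts of compound and lower numbers for an effect already at smaller amounts. Compound 2 `CC#CC(CC(=O)O)c1ccc(OCc2ccc(C(=O)N3CCN(C)CC3)s2)cc1` is reported only as a limit, > 5000 nM, in this assay. Compound 3 `CC#CC(CC(=O)O)c1ccc(OCc2ccc(C(=O)N3CCN(c4ccncc4)CC3)s2)cc1` likewise sits at a limit, > 5000 nM. Two of the three values shown thus rest at the limit of > 5000 nM in this assay, at which 2 of the 3 values shown sit, so compound 2 stands at the weak end of what this assay can report. Compound 4 `CC#CC(CC(=O)O)c1ccc(OCc2ccc(C(=O)N3CCN(c4ccc(C)cc4)CC3)s2)cc1` differs from compound 2 in one place: 4-methylphenyl in place of methyl on an amine nitrogen in a ring. The measured steps run the other way: an at least 69-fold higher number from compound 1 to compound 2 (1.84 log units; beyond the scatter) and an at least 69-fold higher number from compound 1 to compound 3 (1.84 log units; beyond the scatter), while a step that the two limits leave unreadable from compound 2 to compound 3 cannot be read. Compound 3 warns that not every ring on this nitrogen helps. Still, compound 4 is expected to recover much of the ground lost in that large step, estimated at 120 nM with a range from 30 nM to 1500 nM. That expectation amounts to the step of an at least 41-fold lower number from compound 2 to compound 4 (1.61 log units; beyond the scatter).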

Compound 4, half-maximal effective concentration: 211 nM
Compound 4: the middle estimate sits 1.8-fold (0.25 log units) below what was measured; the range from low to high includes it.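

Compound 4 shows that a carbon-only aromatic ring on this ring nitrogen still gives activity when it carries a methyl, with an at least 23-fold lower number from compound 2 to compound 4 (1.37 log units; beyond the scatter) and an at least 23-fold lower number from compound 3 to compound 4 (1.37 log units; beyond the scatter). That added methyl has a cost, however, with a 2.9-fold higher number from compound 1 to compound 4 (0.47 log units; beyond the scatter), so the plain phenyl of compound 1 stays ahead. Compound 2 and compound 3 each rest on a limit, not a number: the limit of > 5000 nM in this assay, at which 2 of the 4 values shown sit.

The compounds shown leave open whether this cost is specific to methyl. A 4-chlorophenyl or 4-methoxyphenyl group on the same nitrogen could answer that.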